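Aryl variation in the series: removing the hydroxy group

The source may hold more compounds than are shown below. What is called first, only, known or untested is meant among the compounds shown, and "the series" means these compounds.

Values in a functional assay on SGC-7901 cells (Homo sapiens) for inhibition, read by MTT assay, with a stated time of 24 h (on this read-out lower numbers stand for stronger inhibition and higher numbers for weaker inhibition), so far:
compound 1 `CC1(C)[C@H]2CC[C@]1(C)N(Cc1cn(-c3ccccc3Br)nn1)C(=O)C2` gives 500 nM
compound 2 `CC1(C)[C@H]2CC[C@]1(C)N(Cc1cn(-c3ccccc3Cl)nn1)C(=O)C2` gives 220 nM
compound 3 `CC1(C)[C@H]2CC[C@]1(C)N(Cc1cn(-c3ccc(O)cc3)nn1)C(=O)C2` gives 330 nM

Compound 3 is not separated from either of the other two measured compounds: the steps are a 1.5-fold lower number from compound 1 to compound 3 (0.18 log units; within the scatter) and a 1.5-fold higher number from compound 2 to compound 3 (0.18 log units; within the scatter) and both stay within the scatter.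

The next step leads to compound 4 `CC1(C)[C@H]2CC[C@]1(C)N(Cc1cn(-c3ccccc3)nn1)C(=O)C2` with hydrogen in place of hydroxy on an aromatic carbon and the rest of the structure unchanged. It reads equally as 4-hydroxyphenyl to phenyl.

Within the data shown here, no measured pair isolates this change. The closest evidence is the exchange of the whole aromatic substituent in the two steps above, neither of which exceeds the scatter. Among the measured compounds shown here, the one step beyond it is a 2.3-fold lower number from compound 1 to compound 2 (0.36 log units; beyond the scatter) and it is modest, so it stands against any claim that substituent changes here do nothing. Three compounds cannot settle more than that.

No step beyond the scatter is therefore expected in this assay and no direction is favoured. The expected step is a 1.1-fold higher number from compound 3 to compound 4 (0.03 log units; within the scatter) as an estimate only. For compound 4 the estimated value is 350 nM with an expected range from 140 nM to 900 nM as its limits.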

Compound 4, half-maximal inhibitory concentration: 240 nM
Estimate against measurement, compound 4: 1.5-fold (0.16 log units) above, and the stated range covers the measured number.
By their numbers in this assay, from the lowest: compounds 2, 4, 3 and 1 (each within the scatter of the next, the first and the last beyond it).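

In this assay, among these compounds, the step of a 1.4-fold lower number from compound 3 to compound 4 (0.14 log units; within the scatter) is the first direct reading of the hydroxy group para to a large group, and it stays within the scatter, so removing this group, with its hydrogen-bond donor and acceptor, has no demonstrated effect on the read-out. The unsubstituted phenyl also gives the halogens a reference point: a 1.1-fold higher number from compound 2 to compound 4 (0.04 log units; within the scatter) stays within the scatter, while a 2.1-fold lower number from compound 1 to compound 4 (0.32 log units; beyond the scatter) lies beyond it and is modest, so among the aromatic substituents only bromo separates from hydrogen. Compound 3 goes against any clean split. It is separated from neither compound 1 nor compound 4. No supporting data on hand bear on why these steps take the sizes they do.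

On these data alone, it remains open whether a substituent of a different kind on this aromatic carbon, such as an amine, a carboxylic acid or a methoxy group, would move the number beyond the scatter from compound 4. Also open, as far as these compounds go, is whether a longer chain in place of the phenyl would leave the read-out equally flat.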